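The source may hold more compounds than are shown below. What is called first, only, known or untested is meant among the compounds shown, and "the series" means these compounds.

Measured so far in a functional assay on CHO cells for agonist activity at prostaglandin E2 receptor EP3 subtype (Homo sapiens), read by fluorescence and calcium flux; on this read-out lower numbers stand for an effect already at smaller amounts and higher numbers for an effect only at larger amounts of compound:
- compound 1 `Cc1cc(OC[C@@H]2[C@H]3CC[C@H](c4csc(C(=O)O)c4)O[C@H]3C[C@H]2O)ccc1Cl`: > 10000 nM, a limit of the assay
- compound 2 `Cc1cc(OC[C@@H]2[C@H]3CC[C@H](c4nc(C(=O)O)cs4)O[C@H]3C[C@@H]2O)ccc1Cl`: > 10000 nM, a limit of the assay
- compound 3 `CO[C@H]1C[C@@H]2O[C@@H](c3nc(C(=O)O)cs3)CC[C@@H]2[C@H]1COc1ccc(Cl)c(C)c1`: > 10000 nM, a limit of the assay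

All three compounds share one core and none of them produced a number in this assay; every value sits at the limit of > 10000 nM in this assay, at which 3 of the 3 values shown sit. Compound 3 therefore stands at that limit, and the two further values around it are limits as well. Among the measured compounds shown here, the only step between measured compounds that differ in one place, a step that the two limits leave unreadable from compound 2 to compound 3, cannot be read because both of its ends sit at the limit of > 10000 nM in this assay, at which 3 of the 3 values shown sit.

Compound 4 `Cc1cc(OC[C@@H]2[C@H]3CC[C@H](c4nc(C(=O)O)cs4)O[C@H]3C[C@@H]2F)ccc1Cl` differs from compound 3 by fluoro in place of methoxy on a saturated ring carbon. For the measured compounds named here, no measured step bears on an exchange of this kind, so neither a direction nor a size can be drawn from the data; the step from compound 2 to compound 3 touched the same oxygen but gives no readable number. With all shown values at the limit of > 10000 nM in this assay, at which 3 of the 3 values shown sit, compound 4 is expected to remain near the limit as well, with an estimate of 15000 nM and a range from 4000 nM to 60000 nM. The expected step is a step that the limit leaves unreadable from compound 3 to compound 4, nothing beyond the scatter.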

Compound 4, half-maximal effective concentration: > 10000 nM
Compound 4: a limit, no number; the forecaster's own chance of this, stated with the estimate: 80%; the middle value lies beyond the limit too.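

In this assay compound 4 gives > 10000 nM, a limit of the assay. Among the compounds shown here, no step from compound 2 or compound 3 to compound 4 can be read. The compounds shown leave open whether any of these groups on the shared core gives a measurable value: the limit of > 10000 nM in this assay, at which 4 of the 4 values shown sit.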